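From ethoxy to tert-butyl on an amine nitrogen

A few compounds are considered here, and "the series" means these few. Any claim that something is new, unique, unknown or untested is made for them only; others in the source may bear on it.

In an in vitro ADME assay on microsomes from liver (Homo sapiens) for metabolic stability, read by LC-MS (on this read-out lower numbers stand for a shorter-lived compound and higher numbers for a longer-lived compound), compound 1 (`CCON/C(=N\C1=NC(=O)C(=O)N1C(C)C)Nc1ccc(Cl)c(Cl)c1`) gives > 1 h as a limit of the assay, not a number. In this assay compound 2 (`CC(C)N1C(=O)C(=O)N=C1/N=C(\NOCc1ccccc1)Nc1ccc(Cl)c(Cl)c1`) gives 0.215 h on the same scale. Going by the values given here, that makes an at least 4.6-fold lower number from compound 1 to compound 2 (0.66 log units; beyond the scatter) the only measured step, and it also alters the ethoxy. Compound 3 (`CC(C)N1C(=O)C(=O)N=C1/N=C(/Nc1ccc(Cl)c(Cl)c1)NC(C)(C)C`) instead has tert-butyl in place of ethoxy on an amine nitrogen, so this different change leaves that step only a loose guide. A modest move toward a lower number is expected (an at least 1.2-fold lower number from compound 1 to compound 3 (0.09 log units; that floor lies within the scatter)), and one within the scatter remains possible. Compound 3 is estimated at 0.8 h (expected range 0.25 h to 2.5 h) in this assay.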

Compound 3, half-life: > 1 h
Compound 3: a limit, no number (the forecaster's own chance of this, stated with the estimate: 40%); middle value at least 1.2-fold (0.09 log units) from the limit.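

In this assay, exchanging benzyloxy for tert-butyl gives an at least 4.6-fold higher number from compound 2 to compound 3 (0.66 log units; beyond the scatter). The short half-life of compound 2 therefore does not follow from every replacement of ethoxy at this position, and compound 3 joins compound 1 at the top limit of the assay. The step between these two cannot be read because both are limits, not numbers: the limit of > 1 h in this assay, at which 2 of the 3 values shown sit.

Which of ethoxy and tert-butyl gives the longer half-life stays open. So does how a shorter methoxy group or a longer propoxy chain would read on this amine nitrogen.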